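This account rests on a few compounds, and the source may have more. Where it says the series, first, only, none or still open, it means among the compounds named here.

Measured so far in an ADME assay on HEK293 cells (Homo sapiens) for cytotoxicity, read by resazurin assay, with a stated time of 48 h; on this read-out lower numbers stand for higher toxicity in this test and higher numbers for lower toxicity in this test:
compound 1 `O=S(=O)(Nc1ccc(-c2nc3ccccc3o2)cc1)c1cccc(F)c1` gives > 100000 nM.
compound 2 `O=S(=O)(Nc1ccc2oc(-c3ccccc3)nc2c1)c1ccc(Cl)c(C(F)(F)F)c1` gives 66000 nM.
compound 3 `O=S(=O)(Nc1ccc2oc(-c3ccccc3)nc2c1)c1cccs1` gives 97000 nM.

The read-out of compound 1 is a limit of this assay and not a number. Compound 1 therefore stands only at the edge of what this assay can report, and its true half-maximal cytotoxic concentration is not known more closely than that; see (the limit of > 100000 nM in this assay, at which 1 of the 3 values shown sits). Compounds 2 and 3 return numbers, and both of them sit close to that same edge, so across the three compounds nothing in this assay separates one from another beyond the usual scatter, and none can be called more or less toxic than the others.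

The next compound in the series is compound 4 `O=S(=O)(Nc1ccc(-c2nc3ccccc3o2)cc1)c1ccc(O)cc1`. It arises from compound 1 by 4-hydroxyphenyl in place of 3-fluorophenyl on a sulfonyl sulfur. Among the measured compounds shown here, no step between measured compounds that touches this part of the molecule is available, so the size of the change can only be guessed from how little this assay has so far distinguished between any members. The step of a number no higher from compound 1 to compound 4 (the limit leaves the size open) is expected to be none beyond the scatter. Compound 4 is expected at 100000 nM, within a range from 50000 nM to 200000 nM, with a real chance that this assay again reports only a limit.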

Compound 4, half-maximal cytotoxic concentration: > 100000 nM
Compound 4: only a limit was reported; the forecaster's own chance of this, stated with the estimate: 60%; the middle value lies on the limit itself.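

In this assay compound 1 and compound 4 both return only a limit and not a number, so the step between them cannot be read: the limit of > 100000 nM in this assay, at which 2 of the 4 values shown sit.

The compounds shown leave open where the true half-maximal cytotoxic concentrations of compound 1 and compound 4 lie, and whether 4-hydroxyphenyl in place of 3-fluorophenyl on a sulfonyl sulfur changes this read-out at all.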